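The source may hold more compounds than are shown below. What is called first, only, known or untested is meant among the compounds shown, and "the series" means these compounds.

Compounds measured so far in an ADME assay on GES1 cells (Homo sapiens) for inhibition, read by MTT assay, with a stated time of 72 h; a lower number here means a stronger inhibitor, a higher number a weaker inhibitor:
compound 1, `Cc1cc(Nc2cc(-c3ccccc3)[nH]n2)n2nc(SCc3ccc(F)cc3)nc2n1`, 35500 nM
compound 2, `Cc1cc(Nc2cc(-c3ccccc3)[nH]n2)n2nc(SCc3c(Cl)cccc3Cl)nc2n1`, 39600 nM
compound 3, `Cc1cc(Nc2cc(-c3ccccc3)[nH]n2)n2nc(SCc3nc4ccccc4[nH]3)nc2n1`, 27800 nM

Compound 1 stands second highest of the three in this assay; its nearest neighbour is compound 2, a 1.1-fold higher number from compound 1 to compound 2 (0.05 log units; within the scatter), its furthest compound 3, a 1.3-fold lower number from compound 1 to compound 3 (0.11 log units; within the scatter). Compound 4, `Cc1ccc(CSc2nc3nc(C)cc(Nc4cc(-c5ccccc5)[nH]n4)n3n2)cc1`, differs from compound 1 by methyl in place of fluoro on an aromatic carbon.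

The measured steps all vary the group on the saturated chain carbon bound to a sulfur: a 1.1-fold higher number from compound 1 to compound 2 (0.05 log units; within the scatter), a 1.3-fold lower number from compound 1 to compound 3 (0.11 log units; within the scatter) and a 1.4-fold lower number from compound 2 to compound 3 (0.15 log units; within the scatter), every one within the scatter. None is the present change, but together they show the series insensitive to this group, so in this assay no step beyond the scatter is expected; the estimated step is a 1.0-fold lower number from compound 1 to compound 4 (0.01 log units; within the scatter). Compound 4 is therefore expected at 35000 nM, within 17000 nM to 70000 nM.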

Compound 4, half-maximal inhibitory concentration: 36200 nM
The estimate for compound 4 lay 1.0-fold (0.01 log units) below the measured number, and the stated range covers the measured number.
By their numbers in this assay, from the lowest: compounds 3, 1, 4 and 2 (each within the scatter of the next).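

Methyl in place of fluoro at the aromatic carbon para to a large group gives a 1.0-fold higher number from compound 1 to compound 4 (0.01 log units; within the scatter) in this assay, the first reading of a change on the ring itself rather than of an exchange of the whole group on the chain carbon. The 4-methylphenyl group also stays within the scatter of the other groups, with a 1.3-fold higher number from compound 3 to compound 4 (0.11 log units; within the scatter) and a 1.1-fold lower number from compound 2 to compound 4 (0.04 log units; within the scatter) as its steps. No supporting measurement bears on this result.

Going by these compounds, whether an amine or a carboxylic acid at this ring carbon would give a step beyond the scatter remains open. The same holds for a longer chain between the sulfur and the ring.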